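The compounds below may be only part of what the source reports. "The series", "measured", "known", "first", "only" and "open" are said of these compounds alone.

Compound 1 `O=C(CCC(=O)OCCCCCCSc1ccc([N+](=O)[O-])c2nonc12)Nc1ccccc1F` is the reference point of this pair. For the measured compounds named here, in an assay on isolated protein for inhibition of glutathione S-transferase Mu 2 (Homo sapiens), with a stated time of 10 min (a lower number here means a stronger inhibitor, a higher number a weaker inhibitor), compound 1 gives 350 nM, the lowest of the two numbers measured so far. Going by the values given here, its only measured neighbour is compound 2 `O=C(CCC(=O)OCCCCCCSc1ccc([N+](=O)[O-])c2nonc12)Nc1ccc(Br)cc1`, which in this assay gives 32000 nM; the step from one to the other is a 91-fold higher number from compound 1 to compound 2 (1.96 log units; beyond the scatter), the single change being 4-bromophenyl in place of 2-fluorophenyl on the amide-type nitrogen.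

Compound 3 `O=C(CCC(=O)OCCCCCCSc1ccc([N+](=O)[O-])c2nonc12)Nc1ccc(C(F)(F)F)cc1` is not yet measured. It differs from compound 1 by 4-(trifluoromethyl)phenyl in place of 2-fluorophenyl on an amide-type nitrogen.

Among the compounds with values here, the one step that bears on this is the move to compound 2, where the 2-fluorophenyl on the amide-type nitrogen was likewise replaced by a phenyl carrying a single group at the 4-position, and the number rose sharply, as a 91-fold higher number from compound 1 to compound 2 (1.96 log units; beyond the scatter) shows. Within the data shown here, no measured step separates the effect of the bromine from that of the trifluoromethyl, so the expectation for compound 3 rests on that one comparison and carries a wide range. A step in the same direction, large, is expected: a 43-fold higher number from compound 1 to compound 3 (1.63 log units; beyond the scatter). Compound 3 is therefore estimated at 15000 nM, within 3000 nM to 60000 nM.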

Compound 3, half-maximal inhibitory concentration: 90 nM
Estimate against measurement, compound 3: 170-fold (2.22 log units) above; measured number outside the range, below it.
By their numbers in this assay, from the lowest: compound 3; then compound 1; then compound 2.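

For the compounds shown here, the loss seen with 4-bromophenyl on the amide-type nitrogen does not carry over to 4-(trifluoromethyl)phenyl: in this assay, that replacement of 2-fluorophenyl gives the series its lowest number so far (a 3.9-fold lower number from compound 1 to compound 3 (0.59 log units; beyond the scatter)). The outcome at this place therefore depends on which group the phenyl carries, not merely on the change from 2-fluorophenyl to a phenyl with a group named at the 4-position, and compound 2 is the one case shown that goes the other way. Exchanging bromo for trifluoromethyl on the aromatic carbon is the largest step in the set (a 360-fold lower number from compound 2 to compound 3 (2.55 log units; beyond the scatter)), yet no measurement of any property of these groups is available to account for it.

Still open, as far as these compounds go, is how an unsubstituted phenyl, a 4-fluorophenyl or a 2-(trifluoromethyl)phenyl would stand on the amide-type nitrogen, since these would help separate the identity of the group from its place on the ring. Also open, from the compounds shown here alone, is whether the order of compound 3, compound 1 and compound 2 would hold with a longer chain between the ester oxygen and the sulfur, as the chain is the same in all three compounds.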